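Changing the Ester Aryl Group of an Antiproliferative Ester

The compounds below may be only part of what the source reports. "The series", "measured", "known", "first", "only" and "open" are said of these compounds alone.

Compound 1 `CC1=CC[C@H](C(C)C)c2cc(C)c(OC(=O)c3ccc(C)cc3)cc21` gives the higher of the two numbers recorded in a functional assay on U-251 cells (Homo sapiens) for antiproliferative activity, read by sulforhodamine B assay, with a stated time of 48 h, tested at 50 uM; a higher number here means more inhibition at the concentration tested (going by the name of the read-out), a lower number less inhibition: compound 1 reaches 67.7%. Compound 3 `Cc1cc2c(C(C)C)ccc(C)c2cc1OC(=O)c1ccc(C(F)(F)F)cc1`, built on a different core, gives 16.5%, a gap that lies beyond the usual scatter of this assay. Compound 2 `Cc1cc2c(C(C)C)ccc(C)c2cc1OC(=O)c1cccc(C(F)(F)F)c1` is reported only as "not active" (no number reported), without a number. Compound 4 `CC1=CC[C@H](C(C)C)c2cc(C)c(OC(=O)c3cccc(Cl)c3)cc21` keeps the core of compound 1 and differs from it by 3-chlorophenyl in place of 4-methylphenyl on a carbonyl carbon. Going by the values given here, no measured pair shows this exact exchange, so its effect cannot be read off directly. A moderate loss of inhibition is expected, a number 22.7 percentage points lower from compound 1 to compound 4 (beyond the scatter). For compound 4 the estimated inhibition is 45%, with a range from 15% to 75%.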

Compound 4, a percentage reported as inhibition, at one concentration (the size of the read-out at that concentration, not a potency): 0.9%
Beside the measured number, compound 4's estimate is 44.1 percentage points above it; measured number outside the range, below it.
By their numbers in this assay, from the lowest: compound 4; then compound 3; then compound 1.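

Within the core of compound 1, the ester aryl group strongly affects inhibition: 3-chlorophenyl in place of 4-methylphenyl on the carbonyl carbon gives a number 66.8 percentage points lower from compound 1 to compound 4 (beyond the scatter) in this assay. The two groups have equal heavy-atom counts and the same kind of aromatic ring, so this large step comes from a change that leaves those counts untouched. Nothing measured here gives a reason for the loss.

The compounds shown do not separate the effect of adding chlorine from that of removing methyl. As far as these compounds go, how an aryl ring carrying an amine, a carboxylic acid or a methoxy group would behave on this core remains open.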